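Replacing 3,4-dihydroxyphenyl with 3-nitrophenyl on a shared core

The source may report more compounds than this note shows. Statements on the series, on what has been measured and on what is new or still open speak of the compounds shown alone.

In a functional assay on HepG2 cells (Homo sapiens) for inhibition, read by MTT assay, with a stated time of 72 h (on this read-out higher numbers stand for weaker inhibition and lower numbers for stronger inhibition), compound 1 `COc1cc(O)c(CC=C(C)C)c(O)c1C(=O)/C=C/c1ccc(O)c(O)c1` gives 15200 nM as the only number among the readings shown. Compound 2 `COc1cc(/C=C/C(=O)c2c(OC)cc(O)c(CC=C(C)C)c2O)cc(OC)c1OC` gives > 50000 nM as a limit of the assay and not a number. Compound 3 `COc1cc(O)c(CC=C(C)C)c(O)c1C(=O)/C=C/c1cccc([N+](=O)[O-])c1` has not yet been measured and differs from compound 1 in one place: 3-nitrophenyl stands in place of 3,4-dihydroxyphenyl on a double-bonded chain carbon bound to a double-bonded chain carbon (3-nitrophenyl in place of 3,4-dihydroxyphenyl on a double-bonded chain carbon bound to a double-bonded chain carbon). Within the data shown here, no measured step between two compounds is available as a guide, and only one number serves as a starting point. The estimated step of a 1.4-fold higher number from compound 1 to compound 3 (0.16 log units; within the scatter) in this assay is therefore expected to stay within the usual scatter, with a wide margin kept on either side. For compound 3 the estimated value is 22000 nM with an expected range from 8000 nM to 50000 nM in this reading.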

Compound 3, half-maximal inhibitory concentration: 16600 nM
The estimate for compound 3 lay 1.3-fold (0.12 log units) above the measured number, and the stated range covers the measured number.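

In this assay, the exchange of 3,4-dihydroxyphenyl for 3-nitrophenyl gives a 1.1-fold higher number from compound 1 to compound 3 (0.04 log units; within the scatter). Among these compounds, this is the first step at this position that can be read as a number, and the two compounds stay within the scatter of each other even though the group that leaves carries hydrogen-bond donors and the group that enters carries none. Compound 2 gives a limit of the assay and not a number, so no step involving it can be read: the limit of > 50000 nM in this assay, at which 1 of the 3 values shown sits.

The compounds shown leave open whether this tolerance extends to other groups at the same place, such as 3-aminophenyl or a phenyl ring bearing a carboxylic acid. They also leave open why the reading stays within the scatter across this change.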